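Taking the Side Group Off Compound 1

The source may report more compounds than this note shows. Statements on the series, on what has been measured and on what is new or still open speak of the compounds shown alone.

Among the compounds with values here, in a functional assay on HL-60 cells (Homo sapiens) for antiproliferative activity, read by MTT assay, with a stated time of 6 days (on this read-out lower numbers stand for stronger inhibition and higher numbers for weaker inhibition), compound 1 `O=C1C=C[C@@H](OCc2ccccc2)[C@@H]([C@@H](COC(=O)/C=C/c2ccccc2)OCc2ccccc2)O1` gives 610 nM, the lowest of the three numbers measured so far. Compound 2 `CC(=O)O[C@@H]1C=CC(=O)O[C@@H]1[C@@H](COC(=O)/C=C/c1ccc(F)cc1)OC(C)=O` gives 1890 nM, and compound 3 `O=C1C=C[C@@H](OC(=O)c2ccccc2)[C@@H]([C@@H](COC(=O)c2ccccc2)OC(=O)c2ccccc2)O1` gives 8250 nM; both gaps to compound 1 lie beyond the usual scatter.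

The next compound to be tested is compound 4 `O=C1C=C[C@@H](OCc2ccccc2)[C@@H]([C@@H](CO)OCc2ccccc2)O1`. It keeps the core of compound 1 but has hydrogen in place of (2-phenylethenyl)carbonyl on an oxygen on a saturated carbon. The ester side chain is thus cut back to a free hydroxy group.

Within the data shown here, no measured pair isolates this change, so the size of the step has to be judged indirectly. Among the measured compounds shown here, the only hint is compound 3, which has no (2-phenylethenyl)carbonyl and gives 8250 nM, though it also differs from compound 1 elsewhere. In this assay, the step expected is a 3.3-fold higher number from compound 1 to compound 4 (0.52 log units; beyond the scatter), a moderate rise towards weaker inhibition, beyond the scatter. For compound 4, the estimated value is 2000 nM, with an expected range of 500 nM to 9000 nM.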

Compound 4, half-maximal inhibitory concentration: 10200 nM
Compound 4: middle estimate off by 5.1-fold (0.71 log units), on the low side; the measured number lies above the stated range.
By their numbers in this assay, from the lowest: compound 1; then compound 2; then compounds 3 and 4 (each within the scatter of the next).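

Within the data shown here, replacing the (2-phenylethenyl)carbonyl on this oxygen with hydrogen gives, in this assay, a 17-fold higher number from compound 1 to compound 4 (1.22 log units; beyond the scatter), a large step and the first reading of this position from a pair that differs in one place only. With the core of compound 1 unchanged, the ((2-phenylethenyl)carbonyl)oxy group is therefore tied to much of the inhibition seen with compound 1, and a plain hydroxy group does not stand in for it. Nothing available explains the size of this step.

From the compounds shown here alone, it remains open whether the part that matters is the aromatic ring, the double bond or the ester link, and a saturated 3-phenylpropanoyl group on this oxygen would test the double bond. An amine in place of this oxygen would show whether the ester link can be exchanged.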